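The source may report more compounds than this note shows. Statements on the series, on what has been measured and on what is new or still open speak of the compounds shown alone.

Measured compounds:
- Compound 1, `Cn1ccc2c(Oc3ccc(NC(=O)c4cn(-c5ccc(Cl)cc5)c5ccccc5c4=O)cc3F)ccnc21`: 2120 nM in a functional assay on MCF7 cells (Homo sapiens) for inhibition, read by MTT assay, with a stated time of 72 h; a higher number here means a weaker inhibitor, a lower number a stronger inhibitor
- Compound 2, `Cn1ccc2c(Oc3ccc(NC(=O)c4cn(-c5ccc(Br)cc5)c5ccccc5c4=O)cc3F)ccnc21`: 1830 nM
- Compound 3, `O=C(Nc1ccc(Oc2ccnc3[nH]ccc23)c(F)c1)c1cn(-c2ccc(Cl)cc2)c2ccccc2c1=O`: "not determined" (no result reported)

Within the first core, the change bromo in place of chloro on an aromatic carbon gives a 1.2-fold lower number from compound 1 to compound 2 (0.06 log units; within the scatter). The second core differs from the first by hydrogen in place of methyl on an aromatic nitrogen; no measured value for compound 3 exists, so the size of that core change is not known.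

Compound 4, `O=C(Nc1ccc(Oc2ccnc3[nH]ccc23)c(F)c1)c1cn(-c2ccc(Br)cc2)c2ccccc2c1=O`, carries the change bromo in place of chloro on an aromatic carbon against compound 3. Among the measured compounds shown here, the place lines of both changes read the same, so this is the same change as the one from compound 1 to compound 2. With compound 3 unmeasured, the expectation for compound 4 rests only on compound 2, which gives 1830 nM, taken as the nearest measured analogue. Compound 4 is therefore estimated at 1800 nM, with a wide range of 500 nM to 6500 nM.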

Compound 4, half-maximal inhibitory concentration: 650 nM
Compound 4: middle estimate off by 2.8-fold (0.44 log units), on the high side; the range from low to high includes it.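

Read in this assay with bromo held in both compounds, hydrogen in place of methyl on an aromatic nitrogen gives a 2.8-fold lower number from compound 2 to compound 4 (0.45 log units; beyond the scatter). The chloro-to-bromo change can be read only in the core of compound 1, as a 1.2-fold lower number from compound 1 to compound 2 (0.06 log units; within the scatter), and with no result for compound 3 the steps to and from it cannot be read, so whether that change carries to the second core, or whether the nitrogen change holds with chloro, is not shown. Nothing measured here accounts for the step from compound 2 to compound 4.

Still open, from the compounds shown here alone, is how a nitrile or an amine in place of bromo would read in either core. Also open, going by these compounds, is how an ethyl group in place of the hydrogen on the aromatic nitrogen would compare.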